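The source may hold more compounds than are shown below. What is called first, only, known or untested is meant among the compounds shown, and "the series" means these compounds.

Among the measured compounds shown here, compound 2 `CC1=C(C(=O)NC(C)C)C(c2ccoc2)NC(=O)N1` stands lowest of the two measured members in an assay on membranes from HEK293 cells for displacement of a labelled ligand from adenosine receptor A2b (Homo sapiens), read by scintillation counting, with a stated time of 30 min, tested at 1 uM (a lower number here means less inhibition, a higher number more inhibition at the concentration tested (going by the name of the read-out)), where compound 2 gives 3%; the nearest number belongs to compound 1 `COC(=O)C1=C(C)NC(=O)NC1c1ccoc1`, which in this assay gives 42%. For the measured compounds named here, the one measured step, a number 39 percentage points lower from compound 1 to compound 2 (beyond the scatter), separates these two. Compound 3 `CCC(CC)OC(=O)C1=C(C)NC(=O)NC1c1ccoc1` is not yet measured; it differs from compound 2 by (pentan-3-yl)oxy in place of isopropylamino on a carbonyl carbon. This change removes the amide of compound 2 and restores an ester, as in compound 1, so the step that bears on it is the same one, a number 39 percentage points lower from compound 1 to compound 2 (beyond the scatter), now read in reverse. Going by the values given here, a rise beyond the scatter is therefore expected in this assay, roughly back to the level of compound 1, with the wider range reflecting that the longer chain has no measured precedent. For compound 3 the expected step is a number 37 percentage points higher from compound 2 to compound 3 (beyond the scatter). Compound 3 is estimated at 40%, in the range 20% to 60%.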

Compound 3, a percentage reported as inhibition, at one concentration (the size of the read-out at that concentration, not a potency): 28%
For compound 3 the middle estimate is 12 percentage points above the measured one, and the stated range covers the measured number.
By their numbers in this assay, from the lowest: compound 2; then compound 3; then compound 1.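

In this assay the ester on this carbonyl carbon proves to be recoverable ground: with (pentan-3-yl)oxy in place of isopropylamino there is a number 25 percentage points higher from compound 2 to compound 3 (beyond the scatter), so the low number of the amide does not carry over to this ester. The two esters also part from each other, with a number 14 percentage points lower from compound 1 to compound 3 (beyond the scatter), which shows that the group on the ester oxygen changes the read-out and not only the choice of ester over amide. No measured data bear on why either step has its size.

Still open, from the compounds shown here alone, is how the number moves with ethyl or a longer straight chain on the ester oxygen, and whether it follows chain size at all. Also open, going by these compounds, is whether a carboxylic acid at this carbonyl carbon, or an amine other than isopropylamino, stays near the amide or reaches the esters.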